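A new group on the sulfonyl sulfur of compound 3

The compounds below may be only part of what the source reports. "The series", "measured", "known", "first", "only" and "open" are said of these compounds alone.

For the measured compounds named here, in a functional assay on K562 cells (Homo sapiens) for inhibition, read by trypan blue exclusion, with a stated time of 72 h (a lower number here means a stronger inhibitor, a higher number a weaker inhibitor), compound 3 `Cn1c(=O)c(S(=O)(=O)c2ccc(Cl)cc2)cc2cnc(Nc3ccc4[nH]ccc4c3)nc21` gives 100 nM, the lowest of the three numbers so far. Compound 2 `Cn1c(=O)c(C(=O)Nc2ccc(F)cc2)cc2cnc(Nc3ccc4[nH]ccc4c3)nc21` gives 5000 nM. Compound 1 `COc1ccc(Nc2ncc3cc(S(=O)(=O)c4ccc(Cl)cc4)c(=O)n(C)c3n2)cc1` gives 15000 nM.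

Compound 4 `Cn1c(=O)c(S(=O)(=O)Nc2ccc(F)cc2F)cc2cnc(Nc3ccc4[nH]ccc4c3)nc21` has not been measured yet. It differs from compound 3 in one place, on a sulfonyl sulfur: (2,4-difluorophenyl)amino in place of 4-chlorophenyl on a sulfonyl sulfur.

Two measured steps can be weighed. The first, a 150-fold lower number from compound 1 to compound 3 (2.18 log units; beyond the scatter), comes from 1H-indol-5-yl in place of 4-methoxyphenyl on a nitrogen, which is not the place that changes now, so it says little here. The second, a 50-fold lower number from compound 2 to compound 3 (1.70 log units; beyond the scatter), comes from (4-chlorophenyl)sulfonyl in place of (4-fluorophenyl)carbamoyl, and it bears more directly. Compound 2, with 5000 nM, also joins its fluorinated phenyl ring through a nitrogen, and compound 4 shares that feature while keeping the sulfonyl. This single comparison suggests a weaker compound, though probably not as weak as compound 2, and it is thin evidence.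

The expected change is an 8.0-fold higher number from compound 3 to compound 4 (0.90 log units; beyond the scatter), towards a higher number. For compound 4 the estimated value is 800 nM, with an expected range from 150 nM to 5000 nM.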

Compound 4, half-maximal inhibitory concentration: 5000 nM
Beside the measured number, compound 4's estimate is 6.3-fold (0.80 log units) below it; the measured number falls inside the stated range.
By their numbers in this assay, from the lowest: compound 3; then compounds 2 and 4 (each within the scatter of the next); then compound 1.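

In this assay, the group on the sulfonyl sulfur turns out to matter a great deal, since replacing 4-chlorophenyl with (2,4-difluorophenyl)amino gives a 50-fold higher number from compound 3 to compound 4 (1.70 log units; beyond the scatter) and so costs as much as the earlier change of the whole side group did. That earlier change, a 50-fold lower number from compound 2 to compound 3 (1.70 log units; beyond the scatter), might have suggested that having a sulfonyl at this place was what counted, but compound 4 keeps the sulfonyl and still loses the low number of compound 3 (100 nM), so the sulfonyl alone does not secure it. No measurement shown here explains the loss.

This single step also changes two things at once: a nitrogen now joins the ring to the sulfur, and two fluorines stand where one chlorine stood, so a (4-chlorophenyl)amino or a 2,4-difluorophenyl group on the sulfonyl sulfur would be needed to tell these apart. As far as these compounds go, how a group with no aromatic ring, such as a morpholine or a short alkyl chain, would behave on this sulfur also remains open.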